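The source may report more compounds than this note shows. Statements on the series, on what has been measured and on what is new or still open speak of the compounds shown alone.

Among the compounds with values here, in a functional assay on BT-474 cells (Homo sapiens) for inhibition, read by fluorescence, with a stated time of 72 h (on this read-out lower numbers stand for stronger inhibition of growth and higher numbers for weaker inhibition of growth), compound 3 (`N[C@H]1CC[C@H](Nc2nc(Nc3ccc(O)cc3)c3ncn(C4CCCCC4)c3n2)CC1`) gives 27300 nM, the highest of the three numbers so far and beyond the scatter of the other two. Compound 4 (`CC(C)CCn1cnc2c(Nc3ccc(O)cc3)nc(N[C@H]3CC[C@H](N)CC3)nc21`) differs from compound 3 in one place, with isopentyl in place of cyclohexyl on an aromatic nitrogen. Within the data shown here, no measured step makes this exchange. Among the measured compounds shown here, the one measured step, a 1.5-fold lower number from compound 1 to compound 2 (0.19 log units; within the scatter), concerns a different place and keeps isopentyl. Both isopentyl compounds have lower numbers, compound 1 (`COc1ccc(Nc2nc(N[C@H]3CC[C@H](N)CC3)nc3c2ncn3CCC(C)C)c(OC)c1`) at 7900 nM and compound 2 (`CC(C)CCn1cnc2c(Nc3ccc(Cl)cc3)nc(N[C@H]3CC[C@H](N)CC3)nc21`) at 5100 nM, but each also differs from compound 3 elsewhere. A moderate move to a lower number is therefore expected, and the estimated step is a 2.5-fold lower number from compound 3 to compound 4 (0.39 log units; beyond the scatter). Compound 4 is estimated at 11000 nM, within a range of 4000 nM to 28000 nM.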

Compound 4, concentration for 50% growth inhibition: 7700 nM
Compound 4: middle estimate off by 1.4-fold (0.15 log units), on the high side, and the stated range covers the measured number.
By their numbers in this assay, from the lowest: compounds 2, 4 and 1 (each within the scatter of the next); then compound 3.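

In this assay, the exchange on the aromatic nitrogen can now be read directly with 4-hydroxyphenyl held constant, and it goes beyond the scatter (a 3.5-fold lower number from compound 3 to compound 4 (0.55 log units; beyond the scatter)). With isopentyl held, the other place shows no change beyond the scatter, either for hydroxy in place of chloro (a 1.5-fold higher number from compound 2 to compound 4 (0.18 log units; within the scatter)) or for 4-hydroxyphenyl in place of 2,4-dimethoxyphenyl (a 1.0-fold lower number from compound 1 to compound 4 (0.01 log units; within the scatter)). Nothing available explains these steps. Still open, going by these compounds, is how a longer chain or a cyclopentyl ring in place of isopentyl on the aromatic nitrogen would read. Also open, on these data alone, is whether the isopentyl gain carries over to compounds with other groups on the second place.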